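The compounds below may be only part of what the source reports. "The series", "measured", "known", "first", "only" and "open" are said of these compounds alone.

The series shares one core, varied at the amine-bearing aryl group and at the substituent on the ring nitrogen. Compound 1 `Cc1nc(Nc2c(C)cc(Cl)cc2Cl)c(=O)n(C(C)C2CC2)n1` carries a dichloro-methyl aryl group, and in an assay on isolated protein for displacement of a labelled ligand from corticotropin-releasing factor receptor 1 (Rattus norvegicus) (a lower number here means a stronger inhibitor, a higher number a weaker inhibitor), compound 1 gives 33 nM. Compound 2 `COc1cc(C)c(Nc2nc(C)nn(C(C)C3CC3)c2=O)c(C)c1` carries a methoxy-dimethyl aryl group, and in this assay compound 2 gives 68 nM. Compound 3 `Cc1nc(Nc2c(Cl)cc(C(F)(F)F)cc2Cl)c(=O)n(C(C)C2CC2)n1` carries a dichloro-trifluoromethyl aryl group, and in this assay compound 3 gives 14 nM, the lowest of the three numbers; its step to compound 1 and its step to compound 2 both lie beyond the scatter, so compound 3 is the most potent of the measured compounds.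

Compound 4 `CCC(C1CC1)n1nc(C)nc(Nc2c(Cl)cc(C(F)(F)F)cc2Cl)c1=O` keeps the aryl group of compound 3 and differs only on the ring-nitrogen substituent: methyl in place of hydrogen on a saturated chain carbon, two bonds along the chain from an aromatic nitrogen and a saturated ring carbon. Among the measured compounds shown here, the change is small in count, and no pair of measured compounds shows what this particular change does. He expects the step from compound 3 to compound 4 to be no change at the digits printed from compound 3 to compound 4 (within the scatter), most likely none beyond the scatter, with no clear direction. On that basis compound 4 is estimated at 14 nM, within a range from 5 nM to 40 nM.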

Compound 4, half-maximal inhibitory concentration: 6.3 nM
For compound 4 the middle estimate is 2.2-fold (0.35 log units) above the measured one; low and high end bracket the measured number.
By their numbers in this assay, from the lowest: compound 4; then compound 3; then compound 1; then compound 2.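

Among the compounds shown here, compound 4 gives the first reading of the ring-nitrogen substituent, since compounds 1, 2 and 3 all carry 1-cyclopropylethyl and differ only at the aryl group. In this assay, the change from 1-cyclopropylethyl to 1-cyclopropylpropyl gives a 2.2-fold lower number from compound 3 to compound 4 (0.35 log units; beyond the scatter), so this saturated chain carbon is a place where a single added methyl moves the number, and it moves it toward stronger inhibition rather than weaker. This rests on one pair carrying the dichloro-trifluoromethyl aryl group, and no measurement at hand explains the shift.

From the compounds shown here alone, whether the same methyl gives a similar step on the dichloro-methyl aryl group of compound 1 or the methoxy-dimethyl aryl group of compound 2 remains open, so the two changes cannot yet be treated as independent of each other. Also open, going by these compounds, is how far the trend runs along the chain: a longer chain such as propyl in place of the ethyl of compound 4, a second cyclopropyl group, or an ether oxygen within the chain could each continue the step, stop it or reverse it.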